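A Ring Closes on the Amine Nitrogen

The source may report more compounds than this note shows. Statements on the series, on what has been measured and on what is new or still open speak of the compounds shown alone.

compound 1 `CCCc1cc(N)c2cc(NC(=O)/C=C/c3ccc(C(C)(C)C)cc3)ccc2n1` — 22 nM
compound 2 `CCCc1cc(NC2CCC2)c2cc(NC(=O)/C=C/c3ccc(C(F)(F)F)cc3)ccc2n1` — 18 nM
compound 3 `CCCc1cc(NC2CC2)c2cc(NC(=O)/C=C/c3ccc(C(F)(F)F)cc3)ccc2n1` — 40 nM

In an assay on isolated protein for displacement of a labelled ligand from melanin-concentrating hormone receptor 1 (Homo sapiens) (a lower number here means a stronger inhibitor, a higher number a weaker inhibitor), compound 3 gives 40 nM, the highest of the three numbers; compound 1 gives 22 nM, within the scatter of compound 3, while compound 2 gives 18 nM, beyond it. Compound 4 `CCCc1cc(N2CCCCC2)c2cc(NC(=O)/C=C/c3ccc(C(F)(F)F)cc3)ccc2n1` differs from compound 3 in one place: piperidin-1-yl in place of cyclopropylamino on an aromatic carbon. Going by the values given here, the only measured step at this position is a 2.2-fold higher number from compound 2 to compound 3 (0.35 log units; beyond the scatter), modest yet beyond the scatter, and it points to a lower number when the ring on the nitrogen grows. Among the compounds with values here, no measured pair speaks to the loss of the hydrogen-bond donor. Compound 4 is therefore expected to show a small step toward a lower number, a 1.6-fold lower number from compound 3 to compound 4 (0.20 log units; within the scatter), with an estimate of 25 nM and a range from 8 nM to 80 nM.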

Compound 4, half-maximal inhibitory concentration: > 4000 nM
Compound 4 gave a limit, no number (the forecaster's own chance of this, stated with the estimate: 3%); middle value at least 160-fold (2.20 log units) from the limit.
By their numbers in this assay, from the lowest: compounds 2, 1 and 3 (each within the scatter of the next, the first and the last beyond it). At a limit, above all of these: compound 4.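

Where cyclobutylamino and cyclopropylamino had differed only modestly, piperidin-1-yl on this aromatic carbon brings large steps in this assay, with an at least 100-fold higher number from compound 3 to compound 4 (2.00 log units; beyond the scatter) and an at least 220-fold higher number from compound 2 to compound 4 (2.34 log units; beyond the scatter). The position is therefore far less forgiving than the earlier step suggested once the nitrogen carries no hydrogen-bond donor and a six-membered ring. Compound 4 gives a limit, not a number: the limit of > 4000 nM in this assay, at which 1 of the 4 values shown sits.

Ring size and the hydrogen-bond donor change together here, so the compounds shown cannot separate them. A cyclohexylamino group, keeping the donor, or a dimethylamino group, losing it without a ring, would pull the two apart.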